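This account rests on a few compounds, and the source may have more. Where it says the series, first, only, none or still open, it means among the compounds named here.

Measured so far in a functional assay on Jurkat cells (Homo sapiens) for activation, with a stated time of 24 h; a lower number here means that less compound is needed, a higher number that more compound is needed for the effect:
- compound 1 `Oc1ccccc1CNc1ccc(-c2ccc(Cl)cc2)cc1`: 2390 nM
- compound 2 `Oc1ccccc1CNc1ccc(-c2ccc(-c3ccccc3)cc2)cc1`: "not active" (no number reported) (no number reported)
- compound 3 `COc1ccc(-c2ccc(NCc3ccccc3O)cc2)cc1`: 580 nM

Compound 3 stands lowest of the two numbers obtained in this assay; its nearest neighbour is compound 1, and the step of a 4.1-fold lower number from compound 1 to compound 3 (0.61 log units; beyond the scatter) lies beyond the scatter, though it is only modest in size. Within the data shown here, compound 2 gives no number in this assay and is reported as not active, so it contributes no step.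

Compound 4 `CC(=O)c1ccc(-c2ccc(NCc3ccccc3O)cc2)cc1` differs from compound 3 in one place: acetyl in place of methoxy on an aromatic carbon. Among the measured compounds shown here, the only measured step that bears on this position is the exchange from compound 1 to compound 3, a 4.1-fold lower number from compound 1 to compound 3 (0.61 log units; beyond the scatter), which shows that this position responds to substitution, but it does not cover acetyl. Compound 2, carrying a larger group here, is not active, which argues against expecting a gain from a bulkier substituent. For the measured compounds named here, with no direct precedent, the expected step of a 2.6-fold higher number from compound 3 to compound 4 (0.41 log units; beyond the scatter) is a modest rise in the number needed, with wide uncertainty in both directions. Compound 4 is therefore estimated at 1500 nM in this assay, in the range 400 nM to 6000 nM.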

Compound 4, half-maximal effective concentration: "not active" (no number reported)
Nothing numeric was reported for compound 4; the estimate stays without a comparison.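

Among these compounds, compound 4, like compound 2, is reported as not active in this assay without a number, so no step from compound 3 to compound 4 can be read. Nothing shown accounts for this result. The compounds shown leave open how far compound 4 lies from compound 3, and which other groups at this place would keep a number.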